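A few compounds are considered here, and "the series" means these few. Any claim that something is new, unique, unknown or untested is made for them only; others in the source may bear on it.

Measured compounds:
Compound 1, `CCN(CC)CCCS(=O)(=O)c1ccc2nc(NC(=O)NC(=O)c3cc(-n4cccn4)ccc3Cl)sc2c1`: 2.1
Compound 2, `CN1CCN(CCCS(=O)(=O)c2ccc3nc(NC(=O)NC(=O)c4ccccc4Cl)sc3c2)CC1`: 1.8
Compound 3, `CN1CCN(CCCS(=O)(=O)c2ccc3nc(NC(=O)NC(=O)c4cc(-n5cccn5)ccc4Cl)sc3c2)CC1`: 2

Of the compounds shown here, three have been measured in a physicochemical assay for lipophilicity; on this read-out lower numbers stand for lower lipophilicity and higher numbers for higher lipophilicity. Compound 3 gives 2 in this assay, and its number sits within the scatter of both of the others: one step is a number 0.10 log units lower from compound 1 to compound 3 (within the scatter), and the other step is a number 0.20 log units higher from compound 2 to compound 3 (within the scatter). Neither of these changes moved the read-out beyond what repeated measurements of one compound would show.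

Compound 4, `CN1CCN(CCCS(=O)(=O)c2ccc3nc(NC(=O)NC(=O)c4cc(-n5cccn5)c(Cl)cc4Cl)sc3c2)CC1`, has not yet been measured. It differs from compound 3 in one place: chloro in place of hydrogen on an aromatic carbon. Going by the values given here, no measured step adds a chlorine, so nothing here speaks directly to this change. The two steps that are known, the swap of the amine at the chain end and the placement of the pyrazolyl ring, each stayed within the scatter, which suggests that single changes at the edge of this shared core have so far left the read-out nearly unchanged. On that basis a small rise, a number 0.50 log units higher from compound 3 to compound 4 (beyond the scatter), is expected in this assay, with a wide range to reflect the lack of a direct precedent. Compound 4 is therefore estimated at 2.5, between 2.1 and 2.9.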

Compound 4, distribution coefficient: 2.3
Compound 4: middle estimate off by 0.20 log units, on the high side, within the range that was stated.
By their numbers in this assay, from the lowest: compounds 2, 3, 1 and 4 (each within the scatter of the next, the first and the last beyond it).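

Putting chloro in place of hydrogen on this aromatic carbon, ortho to a 1H-pyrazol-1-yl group and meta to a chloro group, gives in this assay a step that reads a number 0.30 log units higher from compound 3 to compound 4 (within the scatter). Going by these compounds alone, this is the first view of this carbon and of a chlorine added to the ring: the change stays within what repeated measurements of a single compound would show, so this position tolerates the extra atom with no clear shift in the read-out. It therefore joins the swap of the amine at the chain end and the addition of the 1H-pyrazol-1-yl group as a third single change that stays within the scatter, and no information is available here to explain the size of this step.

The compounds shown leave open whether another group on this same carbon, such as fluoro, methoxy or a nitrile, would move the number beyond the scatter. They also leave open whether chloro here would give a similar step with a different amine at the chain end, such as morpholin-4-yl.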